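This account rests on a few compounds, and the source may have more. Where it says the series, first, only, none or still open, it means among the compounds named here.

In a functional assay on MDA-MB-231 cells (Homo sapiens) for inhibition, read by MTT assay, with a stated time of 72 h (on this read-out higher numbers stand for weaker inhibition and lower numbers for stronger inhibition), compound 1 `Nc1ncnc2c1c(-c1cnc3[nH]ccc3c1)nn2CC(=O)NO` gives > 150000 nM, which is a limit and not a number. Compound 2 `Nc1nc2cc(-c3nn(CCCCCCCCCC(=O)NO)c4ncnc(N)c34)ccc2o1` gives > 50000 nM, also a limit. Compound 3 `Nc1nc2cc(-c3nn(CCC(=O)NO)c4ncnc(N)c34)ccc2o1` gives > 50000 nM, again a limit. For the measured compounds named here, compound 1 therefore has no exact starting value, and no compound here has a measured number.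

Compound 4 `Nc1ncnc2c1c(-c1cnc3[nH]ccc3c1)nn2CCCCCCC(=O)NO` keeps the core of compound 1 and changes in one place: 5-(hydroxycarbamoyl)pentyl in place of hydroxycarbamoyl on a saturated chain carbon bound to an aromatic nitrogen. Here, 5-(hydroxycarbamoyl)pentyl replaces hydroxycarbamoyl on a saturated chain carbon bound to an aromatic nitrogen.

The closest measured evidence on changing this chain is a step that the two limits leave unreadable from compound 2 to compound 3. That step has a different core and gives no size to carry over, so the expectation is weak. The expected direction in this assay is toward a lower number, meaning stronger inhibition, and it rests only on compound 1 sitting at a limit. The expected change is an at least 10-fold lower number from compound 1 to compound 4 (1.00 log units; beyond the scatter), and a further limit remains quite possible. Compound 4 is estimated at 15000 nM, with an expected range from 1500 nM to 100000 nM.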

Compound 4, half-maximal inhibitory concentration: 37700 nM
Beside the measured number, compound 4's estimate is 2.5-fold (0.40 log units) below it; low and high end bracket the measured number.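

In this assay, compound 4 is the only compound shown with a measured number rather than a limit. Compound 1 gives > 150000 nM, and that value is a limit. Exchanging the hydroxycarbamoyl group for the 5-(hydroxycarbamoyl)pentyl group gives an at least 3.9-fold lower number from compound 1 to compound 4 (0.59 log units; beyond the scatter), so this position responds to the change by a measurable amount, and the true step may be larger than printed.

Going by these compounds, the step from compound 2 to compound 3, a chain change on a different core, cannot be read, so the effect of chain length on the core of compound 4 stays open, including whether a longer chain would lower the number further. Also open, on these data alone, is whether a carboxylic acid in place of the hydroxycarbamoyl end of the pentyl chain would keep the lower number.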